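This account rests on a few compounds, and the source may have more. Where it says the series, first, only, none or still open, it means among the compounds named here.

Compound 2, with the structure `COc1ccc(C2OC(c3cc(OC)c(OC)c(OC)c3)=NN2C(C)=O)c(OC)c1`, stands highest among the three compounds measured in a functional assay on PC-3 cells (Homo sapiens) for antiproliferative activity, read by MTT assay, tested at 5 uM; on this read-out lower numbers stand for a weaker effect and higher numbers for a stronger effect at the one concentration tested: compound 2 gives 92%. Compound 3, `COc1cc(C(=O)N/N=C/c2ccccc2F)cc(OC)c1OC`, follows, and in this assay compound 3 gives 81.8%. Compound 1, `COc1cc(C(=O)N/N=C/c2cccc(F)c2)cc(OC)c1OC`, sits furthest away, and in this assay compound 1 gives 64.1%. Among the compounds with values here, the only measured step between compounds that differ in one place is a number 17.7 percentage points higher from compound 1 to compound 3 (beyond the scatter), a modest rise obtained with 2-fluorophenyl in place of 3-fluorophenyl on a carbon with a double bond to nitrogen.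

The unmeasured compound 4, `COc1cc(C2=NN(C(C)=O)C(c3ccccc3F)O2)cc(OC)c1OC`, is derived from compound 2 by the change (2-fluorophenyl in place of 2,4-dimethoxyphenyl on a saturated ring carbon). Within the data shown here, no measured step exchanges a 2,4-dimethoxyphenyl for a 2-fluorophenyl on a saturated ring carbon, so the step from compound 1 to compound 3 bears on it only loosely: it shows that a 2-fluorophenyl is compatible with a strong read-out, as compound 3 with 81.8% confirms. Compound 2 already stands near the top of the range, which leaves little room upward. Compound 4 is therefore expected to show a number 12 percentage points lower from compound 2 to compound 4 (beyond the scatter), a small drop or none beyond the scatter. The estimate for compound 4 in this assay is 80%, ranging from 62% to 93%.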

Compound 4, a percentage reported as inhibition, at one concentration (the size of the read-out at that concentration, not a potency): 31.6%
The estimate for compound 4 lay 48.4 percentage points above the measured number; the measured number lies below the stated range.
By their numbers in this assay, from the lowest: compound 4; then compound 1; then compound 3; then compound 2.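

On the saturated ring carbon that bears the aryl group, 2-fluorophenyl in place of 2,4-dimethoxyphenyl is far from a neutral exchange: in this assay the change gives a number 60.4 percentage points lower from compound 2 to compound 4 (beyond the scatter), a large step. The earlier step lay on a carbon with a double bond to nitrogen and said nothing about this place, whereas the read-out here proves highly sensitive to the group the saturated ring carbon carries. Nothing available explains the size of this drop.

Because the two methoxy groups leave in the same step in which the fluorine enters, the compounds shown do not separate the loss of the one from the arrival of the other. On these data alone, whether an unsubstituted phenyl, a 4-methoxyphenyl or a phenyl carrying an amine at this carbon would hold the read-out also remains open.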